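Nannocystin-like series: capping the hydroxy of compound 2

The compounds below may be only part of what the source reports. "The series", "measured", "known", "first", "only" and "open" are said of these compounds alone.

Compound 1 (`C/C=C(\C)[C@H]1OC(=O)[C@@H](C)NC(=O)[C@H]([C@@H](C)CC)NC(=O)CN(C)C(=O)[C@@H](Cc2ccccc2)N(C)C(=O)[C@H](C)NC(=O)[C@@H](CC(C)C)OC(=O)/C(C)=C/C[C@H](OCSC)[C@@H]1C`) and compound 2 (`C/C=C(\C)[C@H]1OC(=O)[C@@H](C)NC(=O)[C@H]([C@@H](C)CC)NC(=O)CN(C)C(=O)[C@@H](Cc2ccc(Cl)cc2)N(C)C(=O)[C@H](C)NC(=O)[C@@H](CC(C)C)OC(=O)/C(C)=C/C[C@H](O)[C@@H]1C`) are the two reference points in a functional assay on A549 cells (Homo sapiens) for cytotoxicity, read by CellTiter-Blue, with a stated time of 72 h; on this read-out higher numbers stand for weaker inhibition and lower numbers for stronger inhibition. Compound 1 gives 0.00019 nM. Compound 2 gives 0.00001 nM, the lower of the two numbers and beyond the scatter from compound 1. The two structures differ in more than one place, so their gap does not isolate any single change.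

Compound 3 (`C/C=C(\C)[C@H]1OC(=O)[C@@H](C)NC(=O)[C@H]([C@@H](C)CC)NC(=O)CN(C)C(=O)[C@@H](Cc2ccc(Cl)cc2)N(C)C(=O)[C@H](C)NC(=O)[C@@H](CC(C)C)OC(=O)/C(C)=C/C[C@H](OCSC)[C@@H]1C`) keeps the rest of compound 2 and changes one site: (methylsulfanyl)methyl in place of hydrogen on an oxygen on a saturated carbon. A hydroxy becomes (methylsulfanyl)methoxy, on an oxygen on a saturated carbon. For the measured compounds named here, no measured pair shows this change alone, so its size in this assay remains unmeasured. Going by the values given here, the only guide is compound 1, which also carries (methylsulfanyl)methoxy and gives 0.00019 nM, a higher number than compound 2. A moderate rise is therefore expected, with the expected step being a 6.0-fold higher number from compound 2 to compound 3 (0.78 log units; beyond the scatter). For compound 3 the estimated value is 0.00006 nM, with an expected range of 0.00001 nM to 0.0004 nM.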

Compound 3, half-maximal inhibitory concentration: 0.73 nM
Estimate against measurement, compound 3: 12000-fold (4.09 log units) below, and the stated range ends below it.
By their numbers in this assay, from the lowest: compound 2; then compound 1; then compound 3.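

In this assay, this oxygen on a saturated carbon is highly sensitive to capping when the aromatic chloro is present: (methylsulfanyl)methyl in place of hydrogen gives a 73000-fold higher number from compound 2 to compound 3 (4.86 log units; beyond the scatter), a large loss that compound 1 at 0.00019 nM gave no hint of. With (methylsulfanyl)methoxy held constant, chloro in place of hydrogen on an aromatic carbon also gives a large change, a 3800-fold higher number from compound 1 to compound 3 (3.58 log units; beyond the scatter), so a very low number with this cap holds only in the compound without chloro, and the effect of the cap cannot be taken as the same across the two backgrounds. Nothing available bears on why these two changes are so large together.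

Going by these compounds, whether a smaller or differently built cap on the same oxygen, such as methyl, acetyl or a longer alkyl chain, keeps the very low number of compound 2 remains open. The size of the chloro change with the hydroxy kept, and of the capping change without chloro, also remains open, since no pair among these compounds reads either one.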